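A few compounds are considered here, and "the series" means these few. Any claim that something is new, unique, unknown or untested is made for them only; others in the source may bear on it.

The series shares one core: a chain bearing an amine on one aromatic carbon and an aryl group on another. Compound 1 `FC(F)(F)c1ccccc1-c1nc(NCc2ccc(Cl)c(Cl)c2)c2ccccc2n1` gives 10400 nM in an assay on a protein complex for inhibition of ubiquitin carboxyl-terminal hydrolase 1/WD repeat-containing protein 48 (Homo sapiens), read by fluorescence; on this read-out lower numbers stand for stronger inhibition and higher numbers for weaker inhibition. Within the data shown here, compound 2 `FC(F)(F)c1ccccc1-c1nc(NCC#Cc2cccnc2)c2ccccc2n1` gives 8900 nM in this assay, and the only measured step, a 1.2-fold lower number from compound 1 to compound 2 (0.07 log units; within the scatter), concerns the group on the saturated chain carbon bound to a nitrogen on an aromatic ring. Compound 3 `CC(C)c1ccccc1-c1nc(NCc2ccc(-c3cccnc3)cc2)c2ccccc2n1` gives 180 nM in this assay, the lowest of the three numbers; its distance to compound 2 and to compound 1 lies well beyond the scatter, but compound 3 differs from each of them in two places, so no single step accounts for it. Compound 4 `c1cncc(-c2ccc(CNc3nc(-n4ccnc4)nc4ccccc34)cc2)c1` carries the change (1H-imidazol-1-yl in place of 2-isopropylphenyl on an aromatic carbon). Among the measured compounds shown here, the position it alters is identical in compounds 1, 2 and 3, so the step from compound 1 to compound 2 says nothing about it and no measured step bears on it. Given the size of the change, a higher number than that of compound 3 is expected, an 8.3-fold higher number from compound 3 to compound 4 (0.92 log units; beyond the scatter). Compound 4 is therefore estimated at 1500 nM in this assay, within 200 nM to 12000 nM.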

Compound 4, half-maximal inhibitory concentration: "not active" (no number reported)
Nothing numeric was reported for compound 4, so the estimate cannot be set against anything.
By their numbers in this assay, from the lowest: compound 3; then compounds 2 and 1 (each within the scatter of the next).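

Among these compounds, compound 4 is reported as "not active" in this assay with no number, so no step from compound 3 to compound 4 can be read. Nothing shown here bears on this result. The compounds shown leave open how 1H-imidazol-1-yl in place of 2-isopropylphenyl alone shifts the number.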